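A few compounds are considered here, and "the series" means these few. Any claim that something is new, unique, unknown or untested is made for them only; others in the source may bear on it.

In a functional assay on HCT-116 cells (Homo sapiens) for cytotoxicity, read by MTT assay, with a stated time of 24 h (a higher number here means a weaker inhibitor, a lower number a stronger inhibitor), compound 1 `COc1c(-c2ccccc2)c2ccccc2n(Cc2ccc(C(=O)NO)cc2)c1=O` has the entry "not determined" (no result reported). Going by the values given here, compound 2 `CCN(CC)Cc1ccc(Cn2c(=O)c(OCc3ccc(C(=O)NO)cc3)c(-c3ccccc3)c3ccccc32)cc1` gives 11600 nM, the only number available, so it cannot yet be ranked against any other compound. Compound 3 `CCN(CC)Cc1ccc(Cn2c(=O)c(OCc3ccc(C(=O)NO)cc3)c(-c3cccnc3)c3ccccc32)cc1` differs from compound 2 in one place: pyridin-3-yl in place of phenyl on an aromatic carbon. Here, pyridin-3-yl stands in place of phenyl on an aromatic carbon of the shared core. Among the compounds with values here, no measured pair shows what this swap does, so no shift in either direction can be predicted with confidence. The estimated change is a 1.0-fold higher number from compound 2 to compound 3 (0.01 log units; within the scatter), which is expected to stay within the usual scatter of this assay. Compound 3 is expected to give 12000 nM, with an estimated range of 5000 nM to 28000 nM.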

Compound 3, half-maximal inhibitory concentration: 25700 nM
Beside the measured number, compound 3's estimate is 2.1-fold (0.33 log units) below it, and the stated range covers the measured number.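

In this assay, pyridin-3-yl in place of phenyl on this aromatic carbon, opposite the ring nitrogen, gives a 2.2-fold higher number from compound 2 to compound 3 (0.35 log units; beyond the scatter), so this position does respond to the swap, and the response is a modest weakening. Compound 2 alone, as a single number, could not show this. No measurement at hand explains the shift. Still open, going by these compounds, is what pyridin-4-yl, or a phenyl ring carrying an amine or a carboxylic acid, would do at this position, and whether the same swap would have a similar effect with other groups elsewhere on the shared core.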